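This account rests on a few compounds, and the source may have more. Where it says the series, first, only, none or still open, it means among the compounds named here.

Measured compounds:
- Compound 1 `CC(C)S(=O)(=O)NC1CCCN(S(=O)(=O)c2ccc(F)cc2)C1` — 1 mg/kg
- Compound 2 `CC(=O)N1CCN(S(=O)(=O)c2ccc(F)cc2)CC1` — 0.01 mg/kg
- Compound 3 `CCCN1CCN(S(=O)(=O)c2ccc(F)cc2)CC1` — 1 mg/kg

These three compounds were tested in a functional assay on the whole organism with Mus musculus as the target, with a stated time of 30 min; a higher number here means that more compound is needed for the effect, a lower number that less compound is needed. Compound 1 gives 1 mg/kg and stands level with compound 3, which gives 1 mg/kg; together they hold the highest numbers of the three, so they need the most compound for the effect. Compound 2 lies far from both, with 0.01 mg/kg.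

The step now followed leads from compound 1 to the unmeasured compound 4 `CC(=O)NC1CCCN(S(=O)(=O)c2ccc(F)cc2)C1`. The change is acetyl in place of isopropylsulfonyl on an amine nitrogen. It puts an acetyl group onto compound 1 in place of the isopropylsulfonyl group.

Among the measured compounds shown here, only one measured step says something about this. From compound 2 to compound 3 the acetyl group is replaced by propyl, and the result is a 100-fold higher number from compound 2 to compound 3 (2.00 log units; beyond the scatter). Read the other way, an acetyl group in that position goes with a much lower number. The place is not the same as in compound 4, where the acetyl sits on an amine nitrogen whose other neighbour is a saturated ring carbon, so the comparison is only a loose guide.

On this basis a moderate move toward a lower number is expected, a 3.3-fold lower number from compound 1 to compound 4 (0.52 log units; beyond the scatter). Compound 4 is estimated at 0.3 mg/kg, with a range from 0.03 mg/kg to 3 mg/kg.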

Compound 4, minimum effective dose: 1 mg/kg
Compound 4: middle estimate off by 3.3-fold (0.52 log units), on the low side; the measured number falls inside the stated range.
By their numbers in this assay, from the lowest: compound 2; then compounds 1, 3 and 4 (each within the scatter of the next).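

In this assay, replacing isopropylsulfonyl with acetyl on an amine nitrogen whose other neighbour is a saturated ring carbon gives no change at the digits printed from compound 1 to compound 4 (within the scatter), so at this position the two groups cannot be told apart, although acetyl has 3 heavy atoms and isopropylsulfonyl has 6. Among the compounds shown here, the only earlier step, a 100-fold higher number from compound 2 to compound 3 (2.00 log units; beyond the scatter), had linked acetyl with a much lower number when it sat on an amine nitrogen in a ring, and the new step shows that acetyl does not bring such a drop with it at this other position, so the earlier effect cannot simply be carried over from one place to the other. Nothing available here explains why the same group behaves so differently in these two settings.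

Going by these compounds, it remains open whether a free amine, a methylsulfonyl group or a longer acyl chain such as butanoyl on this nitrogen would stay level with compound 1 and compound 4 or move away from them. Also open, on these data alone, is how isopropylsulfonyl itself would compare with acetyl and propyl on the amine nitrogen in a ring.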